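This account rests on a few compounds, and the source may have more. Where it says the series, first, only, none or still open, it means among the compounds named here.

Compound 3 `CN(N)c1nn2c(=O)cc(C(F)(F)F)nc2s1` stands with the highest number of the three compounds in an assay on cells for inhibition of alkaline phosphatase, tissue-nonspecific isozyme (Homo sapiens), read by luminescence, with stated times of 7 min and 20 min (on this read-out higher numbers stand for weaker inhibition and lower numbers for stronger inhibition), where compound 3 gives 2020 nM. Compound 2 `CCCNc1nn2c(=O)cc(C(F)(F)F)nc2s1` gives 1440 nM, and compound 1 `C=CCNc1nn2c(=O)cc(C(F)(F)F)nc2s1` gives 290 nM. The step of a 7.0-fold higher number from compound 1 to compound 3 (0.84 log units; beyond the scatter) lies beyond the scatter, whereas a 1.4-fold higher number from compound 2 to compound 3 (0.15 log units; within the scatter) lies within it. Compound 4 `O=c1cc(C(F)(F)F)nc2sc(-c3ccccc3F)nn12` differs from compound 3 by 2-fluorophenyl in place of amino(methyl)amino on an aromatic carbon. Within the data shown here, none of the measured steps bears directly on this change: a 5.0-fold higher number from compound 1 to compound 2 (0.70 log units; beyond the scatter) and a 1.4-fold higher number from compound 2 to compound 3 (0.15 log units; within the scatter) compare nitrogen-bound chains or a hydrazine group at this carbon, and no measured compound carries an aromatic ring there. As far as these compounds go, the whole spread from compound 1 to compound 3 is modest, so a large move is not expected, yet the direction stays open. The author expects compound 4 to show a step of a 2.0-fold lower number from compound 3 to compound 4 (0.31 log units; beyond the scatter), an estimate with little support in the data. The estimated value for compound 4 in this assay is 1000 nM, with a range from 150 nM to 6000 nM.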

Compound 4, half-maximal inhibitory concentration: > 100000 nM
Compound 4: a limit, no number; the forecaster's own chance of this, stated with the estimate: 10%; middle value at least 100-fold (2.00 log units) from the limit.
By their numbers in this assay, from the lowest: compound 1; then compounds 2 and 3 (each within the scatter of the next). At a limit, above all of these: compound 4.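

Compound 4 gives no number in this assay, only a limit of the assay: the limit of > 100000 nM in this assay, at which 1 of the 4 values shown sits. With 2-fluorophenyl on this aromatic carbon, the steps are large: an at least 49-fold higher number from compound 3 to compound 4 (1.69 log units; beyond the scatter), an at least 69-fold higher number from compound 2 to compound 4 (1.84 log units; beyond the scatter) and an at least 340-fold higher number from compound 1 to compound 4 (2.53 log units; beyond the scatter). The earlier compounds showed only modest differences among groups joined to this carbon through nitrogen, whereas this change shows that the position does not accept every replacement, at least in the one compound shown with an aromatic ring there.

The compounds shown leave open whether the result follows from the 2-fluorophenyl group as a whole, from its fluorine, or from the loss of a nitrogen on this carbon. A plain phenyl group and an anilino group, which joins a benzene ring through nitrogen, would help separate these possibilities.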